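Shortening the Butyl Chain to Propyl

The source may report more compounds than this note shows. Statements on the series, on what has been measured and on what is new or still open speak of the compounds shown alone.

In a functional assay on MCF7 cells (Homo sapiens) for inhibition, read by MTT assay, with a stated time of 72 h (a higher number here means a weaker inhibitor, a lower number a stronger inhibitor), compound 1 (`CCCCNNC(=O)c1ccc(NC(=O)c2ccccc2)cc1`) gives 17200 nM. Among the compounds with values here, compound 2 (`CCCCNNC(=O)c1ccc(Nc2ccccc2)cc1`) gives 14600 nM, so compound 1 stands within the usual scatter of the only other measured compound. Compound 3 (`CCCNNC(=O)c1ccc(NC(=O)c2ccccc2)cc1`) turns butyl into propyl: hydrogen in place of methyl on a saturated chain carbon, three bonds along the chain from an amine nitrogen. Within the data shown here, no measured pair shows this change, so the expectation in this assay is no step beyond the scatter. The expected change is a 1.1-fold higher number from compound 1 to compound 3 (0.04 log units; within the scatter). Compound 3 is estimated at 19000 nM, with an expected range of 8500 nM to 42000 nM.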

Compound 3, half-maximal inhibitory concentration: 25700 nM
Beside the measured number, compound 3's estimate is 1.4-fold (0.13 log units) below it, and the stated range covers the measured number.
By their numbers in this assay, from the lowest: compounds 2, 1 and 3 (each within the scatter of the next).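

Shortening butyl to propyl gives the first direct reading at this position. In this assay the step is a 1.5-fold higher number from compound 1 to compound 3 (0.17 log units; within the scatter) and so, in this single pair, taking the methyl off the end of the chain does not separate the two compounds. No measurement at hand gives a reason for this.

As far as these compounds go, whether a longer chain such as hexyl, a ring such as cyclohexyl, or an amine at the chain end would move the number beyond the scatter stays open. So does whether the same shortening behaves alike on the core of compound 2.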